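The source may hold more compounds than are shown below. What is called first, only, known or untested is meant among the compounds shown, and "the series" means these compounds.

Compound 1 `O=c1cc(-c2ccccc2)oc2cc(O)c(OCCCN3CCCCC3)c(O)c12`: > 100000 nM, a limit of the assay.
Compound 2 `O=c1cc(-c2ccccc2)oc2cc(OCc3ccccc3)c(OCCCN3CCCCC3)c(O)c12`: 3100 nM.
Compound 3 `COc1cc2oc(-c3ccccc3)cc(=O)c2c(O)c1OCCCN1CCCCC1`: 17000 nM.

In a functional assay on A549 cells (Homo sapiens) for antiproliferative activity, read by MTT assay, with a stated time of 48 h (on this read-out higher numbers stand for weaker inhibition and lower numbers for stronger inhibition), compound 2 has the lowest of the measured numbers, at 3100 nM. The nearest number comes with a 5.5-fold higher number from compound 2 to compound 3 (0.74 log units; beyond the scatter). Compound 1 gives only a limit of the assay, > 100000 nM.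

Compound 4 `CN1CCN(CCCOc2c(OCc3ccccc3)cc3oc(-c4ccccc4)cc(=O)c3c2O)CC1` has not yet been measured. It keeps the core of compound 2 and exchanges one end group: 4-methylpiperazin-1-yl in place of piperidin-1-yl on a saturated chain carbon, three bonds along the chain from an oxygen on an aromatic ring. Thus 3-(piperidin-1-yl)propyl becomes 3-(4-methylpiperazin-1-yl)propyl, while the benzyl group stays in place.

The measured steps bear on this change only indirectly. All of them alter the group on a different oxygen on an aromatic ring: an at least 32-fold lower number from compound 1 to compound 2 (1.50 log units; beyond the scatter) is large, and an at least 5.8-fold lower number from compound 1 to compound 3 (0.76 log units; beyond the scatter) is at least modest. Among the compounds with values here, all three measured compounds carry piperidin-1-yl, so no measured step shows what exchanging it does. A small step is therefore expected, most likely within the scatter, with a slight lean towards a higher number. The expectation stays anchored on compound 2 at 3100 nM. The expected step is a 1.5-fold higher number from compound 2 to compound 4 (0.16 log units; within the scatter). Compound 4 is estimated at 4500 nM, with an expected range from 1500 nM to 14000 nM.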

Compound 4, half-maximal inhibitory concentration: 1300 nM
Compound 4: middle estimate off by 3.5-fold (0.54 log units), on the high side; the whole stated range lies above it.
By their numbers in this assay, from the lowest: compound 4; then compound 2; then compound 3. At a limit, above all of these: compound 1.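

In this assay, the exchange of piperidin-1-yl for 4-methylpiperazin-1-yl on a saturated chain carbon, three bonds along the chain from an oxygen on an aromatic ring, gives a 2.4-fold lower number from compound 2 to compound 4 (0.38 log units; beyond the scatter). Within the data shown here, the earlier compounds all carried piperidin-1-yl and differed only in the group on a different oxygen on an aromatic ring, so this step is the first to show that the end of the 3-carbon-named propyl chain also moves the read-out, here towards stronger inhibition with the benzyl group held in place. Nothing in the data shown accounts for the size or direction of this step.

The compounds shown leave open whether the same exchange would give a similar step with hydrogen or methyl in place of the benzyl group, since this pair is the only one that reads the change. They also leave open how other end groups on the chain, such as a morpholine or a dimethylamine, or a shorter or longer chain carrying 4-methylpiperazin-1-yl, would compare with compound 4.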